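Moving the ring nitrogen on the ethynyl substituent

The compounds below may be only part of what the source reports. "The series", "measured", "known", "first", "only" and "open" are said of these compounds alone.

Compound 3 `CONc1nc(C#Cc2ccccn2)nc2c1ncn2[C@@H]1O[C@H](CO)[C@@H](O)[C@H]1O`: 437 nM
Compound 2 `CONc1nc(C#CC2CCCCC2O)nc2c1ncn2[C@@H]1O[C@H](CO)[C@@H](O)[C@H]1O`: 34 nM
Compound 1 `CCC(=O)[C@H]1O[C@@H](n2cnc3c(N)nc(C#Cc4ccccc4)nc32)[C@H](O)[C@@H]1O`: 3920 nM

In an assay on CHO cells for displacement of a labelled ligand from adenosine receptor A1 (Homo sapiens) (on this read-out lower numbers stand for stronger inhibition and higher numbers for weaker inhibition), compound 3 stands second highest of the three numbers, above compound 2 and below compound 1. Compound 4 `CONc1nc(C#Cc2ccncc2)nc2c1ncn2[C@@H]1O[C@H](CO)[C@@H](O)[C@H]1O` differs from it by pyridin-4-yl in place of pyridin-2-yl on a triple-bonded carbon. Within the data shown here, no measured step compares two such rings on the triple-bonded carbon. Among the measured compounds shown here, the only step at that place, a 13-fold higher number from compound 2 to compound 3 (1.11 log units; beyond the scatter), shows that the group there can move this assay strongly, but it exchanges a saturated ring for an aromatic one and gives no direction for a ring isomer. The step of a 1.1-fold higher number from compound 3 to compound 4 (0.06 log units; within the scatter) is therefore expected to stay within the scatter, with wide uncertainty. Compound 4 is estimated at 500 nM, between 150 nM and 1600 nM.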

Compound 4, inhibition constant: 1190 nM
Beside the measured number, compound 4's estimate is 2.4-fold (0.38 log units) below it, within the range that was stated.
By their numbers in this assay, from the lowest: compound 2; then compound 3; then compound 4; then compound 1.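

In this assay the place of the ring nitrogen alone matters on the triple-bonded carbon: pyridin-4-yl in place of pyridin-2-yl gives a 2.7-fold higher number from compound 3 to compound 4 (0.44 log units; beyond the scatter) with the same atoms joined differently. The change from 2-hydroxycyclohexyl gives a 35-fold higher number from compound 2 to compound 4 (1.54 log units; beyond the scatter) and so exceeds the change to pyridin-2-yl, which makes pyridin-4-yl the poorer of the two rings here. No evidence at hand accounts for the gap between the two ring isomers.

Still open, as far as these compounds go, is where pyridin-3-yl would fall on this triple-bonded carbon. Also open, from the compounds shown here alone, is whether plain cyclohexyl, without the hydroxyl, would stay close to compound 2.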